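The compounds below may be only part of what the source reports. "The series", "measured", "known", "first", "only" and "open" are said of these compounds alone.

In a functional assay on the whole organism for inhibition, with Rattus norvegicus as the target, read by paw edema, with stated times of 1 h and 3 h (on this read-out higher numbers stand for an effect only at larger amounts of compound and lower numbers for an effect already at smaller amounts), compound 1 `C/C(=N\OCC(N)=O)c1ccc(Cl)cc1` gives 24 mg/kg and compound 2 `C/C(=N\OCC(N)=O)c1ccc(Br)cc1` gives 62 mg/kg, so compound 1 holds the lower of the two numbers. Compound 3 `CCOC(=O)CO/N=C(\C)c1ccc(Cl)cc1` keeps the core of compound 1 but differs in one group: ethoxy in place of amino on a carbonyl carbon. Put simply, the carbamoyl of compound 1 becomes ethoxycarbonyl in compound 3. Among the measured compounds shown here, the only measured step available as a guide is a 2.6-fold higher number from compound 1 to compound 2 (0.41 log units; beyond the scatter). That step is bromo in place of chloro on an aromatic carbon, a different place from this change, so it offers a rough size but no direction. A modest step towards a higher number is expected, though this direction is only a tentative guess. The estimated step is a 2.1-fold higher number from compound 1 to compound 3 (0.32 log units; beyond the scatter). For compound 3, the expected value is 50 mg/kg, with an estimated range from 18 mg/kg to 130 mg/kg.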

Compound 3, dose for half-maximal effect: 32 mg/kg
Compound 3: middle estimate off by 1.6-fold (0.19 log units), on the high side; low and high end bracket the measured number.
By their numbers in this assay, from the lowest: compounds 1, 3 and 2 (each within the scatter of the next, the first and the last beyond it).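

In this assay, the change from carbamoyl to ethoxycarbonyl on the shared core comes with a 1.3-fold higher number from compound 1 to compound 3 (0.12 log units; within the scatter), so this swap cannot be distinguished from repeat-measurement scatter. The amino group and its hydrogen-bond donor leave and a larger ethoxy group enters, yet the number stays close to that of compound 1, so in this read-out the donor on this carbonyl carbon does not appear to be required, whereas the halogen swap elsewhere gave a 2.6-fold higher number from compound 1 to compound 2 (0.41 log units; beyond the scatter), a step beyond the scatter. Nothing measured here explains why this position accepts the swap.

As far as these compounds go, it remains open whether a carboxylic acid, a methoxy group or a longer chain on the same carbonyl carbon would also stay this close to compound 1. From the compounds shown here alone, it is also open whether ethoxy in place of amino would behave the same way in the bromo compound 2.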